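Swapping 4-methylbenzyl for phenoxy on a saturated ring carbon

The compounds below may be only part of what the source reports. "The series", "measured", "known", "first", "only" and "open" are said of these compounds alone.

In an ADME assay on the whole organism with Mus musculus as the target, in the formalin test (a lower number here means that less compound is needed, a higher number that more compound is needed for the effect), compound 1 `O=C(c1cc(=O)c2cc(O)ccc2[nH]1)N1CCC(Cc2ccc(F)cc2)CC1` gives 9.5 mg/kg and compound 2 `Cc1ccc(CC2CCN(C(=O)c3cc(=O)c4cc(O)ccc4[nH]3)CC2)cc1` gives 10.6 mg/kg. Among the measured compounds shown here, these two values lie within the usual scatter of each other, so compound 2 cannot be told apart from compound 1 on the only numbers available. Compound 3 `O=C(c1cc(=O)c2cc(O)ccc2[nH]1)N1CCC(Oc2ccccc2)CC1` keeps the shared core but carries a different group: phenoxy in place of 4-methylbenzyl on a saturated ring carbon. In words, this is phenoxy in place of 4-methylbenzyl on a saturated ring carbon. For the measured compounds named here, only one measured step exists, a 1.1-fold higher number from compound 1 to compound 2 (0.05 log units; within the scatter), with methyl in place of fluoro on an aromatic carbon. That step lies within the scatter, but it left the group's connection to the saturated ring carbon unchanged, so it bears only weakly on the new change and gives no direction for it. With so little evidence, no shift beyond the scatter is expected, and the estimated move is a 1.2-fold higher number from compound 2 to compound 3 (0.09 log units; within the scatter). In this assay the estimate for compound 3 is 13 mg/kg, with an expected range from 5 mg/kg to 35 mg/kg.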

Compound 3, dose for half-maximal effect: 8.5 mg/kg
For compound 3 the middle estimate is 1.5-fold (0.18 log units) above the measured one, and the stated range covers the measured number.
By their numbers in this assay, from the lowest: compounds 3, 1 and 2 (each within the scatter of the next).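

In this assay, placing phenoxy on the saturated ring carbon gives a 1.2-fold lower number from compound 2 to compound 3 (0.10 log units; within the scatter), and the comparison with the 4-fluorobenzyl group gives a 1.1-fold lower number from compound 1 to compound 3 (0.05 log units; within the scatter). The earlier step changed only a group on the aromatic ring, whereas these two steps change the group attached to the saturated ring carbon, bringing in an oxygen and one hydrogen-bond acceptor by count, and even so the three compounds cannot be told apart in this test. The data on hand offer no explanation for this result.

As far as these compounds go, all three compounds carry one six-membered aromatic ring of carbon only at this position, so it remains open whether such a ring is needed at all, or whether an amine, a carboxylic acid or a plain alkyl chain in its place would move the dose beyond the scatter. It is also open whether a substituent on the phenoxy ring, such as chloro or methoxy, would shift the number, since the only phenoxy group shown has none.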